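A few compounds are considered here, and "the series" means these few. Any claim that something is new, unique, unknown or untested is made for them only; others in the source may bear on it.

Compound 1 `CCCCCCOC(=O)c1cccc(-c2ccc(OCC)cc2)c1` gives 48% in an assay on COS-7 cells for inhibition of patatin-like phospholipase domain-containing protein 2 (Mus musculus), tested at 200 uM; a higher number here means more inhibition at the concentration tested (going by the name of the read-out), a lower number less inhibition. Compound 2 `CCOc1ccc(-c2cccc(C(=O)OCCOCCOC)c2)cc1` gives 43%. Compound 3 `CCOc1ccc(-c2cccc(C(=O)NC)c2)cc1` gives 40%.

Compound 3 carries a methylcarbamoyl group on the shared core. Its numbers sit close to the other two: the step of a number 8 percentage points lower from compound 1 to compound 3 (within the scatter) and the step of a number 3 percentage points lower from compound 2 to compound 3 (within the scatter) both lie within the scatter, as does a number 5 percentage points lower from compound 1 to compound 2 (within the scatter).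

Compound 4 `CCNC(=O)c1cccc(-c2ccc(OCC)cc2)c1` differs from compound 3 by methyl in place of hydrogen on a saturated chain carbon bound to an amide-type nitrogen. Among the measured compounds shown here, no measured step touches the carbon bound to the amide-type nitrogen; the three measured steps, all larger changes on the carbonyl carbon or along the ester chain, stayed within the scatter. A step of no change at the digits printed from compound 3 to compound 4 (within the scatter) is therefore expected, that is, none beyond the scatter. Compound 4 is estimated at 40%, between 25% and 55%.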

Compound 4, a percentage reported as inhibition, at one concentration (the size of the read-out at that concentration, not a potency): 62%
The estimate for compound 4 lay 22 percentage points below the measured number, outside the stated range (above it).
By their numbers in this assay, from the lowest: compounds 3, 2 and 1 (each within the scatter of the next); then compound 4.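

In this assay, among the compounds shown here, a single added methyl on the saturated chain carbon bound to the amide-type nitrogen gives the first step beyond the scatter, a number 22 percentage points higher from compound 3 to compound 4 (beyond the scatter), although larger changes on the carbonyl carbon had stayed within it. Ethylamino on the carbonyl carbon also stands apart from both ester groups, with a number 19 percentage points higher from compound 2 to compound 4 (beyond the scatter) and a number 14 percentage points higher from compound 1 to compound 4 (beyond the scatter). Nothing measured here explains this gain. On these data alone, whether a longer chain such as propyl, or a branched isopropyl group, would raise the number further remains open.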